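Fluoro in place of hydrogen on the phenyl ring

A few compounds are considered here, and "the series" means these few. Any claim that something is new, unique, unknown or untested is made for them only; others in the source may bear on it.

- compound 1 `Cc1cc(=O)c2c(O)c(CN3CCCC3CO)c(O)c([C@H]3CCN(C)C[C@H]3O)c2o1` gives 13% in growth inhibition
- compound 2 `CN1CC[C@H](c2c(O)cc(O)c3c(=O)cc(/C=C/c4ccccc4)oc23)[C@H](O)C1` gives 87% in growth inhibition

In a functional assay on MIA PaCa-2 cells (Homo sapiens) for inhibition, read by MTT assay, with a stated time of 48 h, tested at 10 uM (on this read-out higher numbers stand for more inhibition of growth at the one concentration tested and lower numbers for less inhibition of growth), compound 2 holds the higher of the two numbers, and its gap to compound 1 lies beyond the scatter. Compound 3 `CN1CC[C@H](c2c(O)cc(O)c3c(=O)cc(/C=C/c4ccccc4F)oc23)[C@H](O)C1` differs from compound 2 in one place: fluoro in place of hydrogen on an aromatic carbon, ortho to a large group (fluoro in place of hydrogen on an aromatic carbon), so that phenyl becomes 2-fluorophenyl. Among the measured compounds shown here, no measured pair shows a step of this kind, so the expectation rests on the small size of the change alone. In this assay no step beyond the scatter is expected, with a slight downward drift at most from the high value of compound 2 (87%). The estimated step is a number 7 percentage points lower from compound 2 to compound 3 (within the scatter) and stays within the scatter. Compound 3 is expected at 80% (estimated range 60% to 93%).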

Compound 3, percent growth inhibition at one concentration: 60%
For compound 3 the middle estimate is 20 percentage points above the measured one, within the range that was stated.
By their numbers in this assay, from the lowest: compound 1; then compound 3; then compound 2.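

In this assay the change from phenyl to 2-fluorophenyl gives a number 27 percentage points lower from compound 2 to compound 3 (beyond the scatter) and so shows that growth inhibition in this series responds to a single fluoro on the ring of the 2-phenylethenyl arm. Among the compounds shown here, this is the first step confined to one place, and it shows that this position, ortho to a large group, does not tolerate every replacement of hydrogen without change. Nothing measured here bears on what lies behind the step.

Chloro or methoxy at the same place would help show whether the step belongs to fluoro or to any group there. Fluoro elsewhere on the aromatic ring would show whether the step is tied to this position.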